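Third methoxy on compound 3

This account rests on a few compounds, and the source may have more. Where it says the series, first, only, none or still open, it means among the compounds named here.

In an ADME assay on MDBK cells (Bos taurus) for cytotoxicity, read by MTT assay, with a stated time of 96 h (on this read-out lower numbers stand for higher toxicity in this test and higher numbers for lower toxicity in this test), compound 1 (`O=[N+]([O-])c1ccccc1-c1nc2ccccc2[nH]1`) gives > 100000 nM, which is a limit of the assay. Compound 2 (`O=[N+]([O-])c1ccc(-c2nc3ccccc3[nH]2)c([N+](=O)[O-])c1`) gives 20000 nM. Compound 3 (`COc1cc(OC)cc(-c2nc3cc(C(F)(F)F)ccc3[nH]2)c1`) gives > 100000 nM, also a limit. Compound 3 thus stands at the limit of > 100000 nM in this assay, at which 2 of the 3 values shown sit.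

Compound 4 (`COc1cc(-c2nc3cc(C(F)(F)F)ccc3[nH]2)cc(OC)c1OC`) differs from compound 3 by methoxy in place of hydrogen on an aromatic carbon, with methoxy in place of hydrogen on an aromatic carbon.

Among the compounds with values here, the only measured step of this kind is an at least 5.0-fold lower number from compound 1 to compound 2 (0.69 log units; beyond the scatter), with nitro entering in place of hydrogen. The entering group and the core both differ here, so a smaller move to lower numbers is expected in this assay, possibly none beyond the scatter. The expected change is an at least 1.2-fold lower number from compound 3 to compound 4 (0.09 log units; that floor lies within the scatter). Compound 4 is expected at 80000 nM, with an estimated range of 25000 nM to 150000 nM.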

Compound 4, half-maximal cytotoxic concentration: 18000 nM
Compound 4: middle estimate off by 4.4-fold (0.65 log units), on the high side; measured number below the stated range.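

In this assay, methoxy in place of hydrogen, ortho to two methoxy groups and para to a large group, gives an at least 5.5-fold lower number from compound 3 to compound 4 (0.74 log units; beyond the scatter). A move to lower numbers beyond the scatter is therefore no longer seen with nitro alone. The value of compound 3 is a limit, so this step gives only a floor for the size of the change: the limit of > 100000 nM in this assay, at which 2 of the 4 values shown sit.

On these data alone, whether a hydroxyl or an ethoxy at this position gives a similar move remains open. Also open, as far as these compounds go, is whether the entering methoxy would give this move without the two methoxy groups already present.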